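The compounds below may be only part of what the source reports. "The series", "measured", "known", "first", "only" and "open" are said of these compounds alone.

Measured in a functional assay on HeLa cells (Homo sapiens) for antiproliferative activity, read by sulforhodamine B assay (a higher number here means a weaker inhibitor of growth, a lower number a stronger inhibitor of growth), so far:
- compound 1 `CC[C@@H]1O[C@H](COCc2ccccc2)[C@@H](OCc2ccccc2)[C@H](OCc2ccccc2)[C@H]1O` gives 19800 nM
- compound 2 `CC[C@H]1O[C@H](COCc2ccccc2)[C@@H](OCc2ccccc2)[C@H](OCc2ccccc2)[C@H]1O` gives > 50000 nM (a limit of the assay, not a number)
- compound 3 `CC[C@@H]1O[C@H](COCc2ccccc2)[C@@H](OCc2ccccc2)[C@H](OCc2ccccc2)[C@H]1OC(C)=O` gives > 50000 nM (a limit of the assay, not a number)

Going by the values given here, compound 1 holds the only true number here, and the rest of the picture is the limit of > 50000 nM in this assay, at which 2 of the 3 values shown sit. Compound 4 `C=CC[C@@H]1O[C@H](COCc2ccccc2)[C@@H](OCc2ccccc2)[C@H](OCc2ccccc2)[C@H]1O` keeps the core of compound 1 and turns its ethyl into allyl, which is vinyl in place of methyl on a saturated chain carbon bound to a saturated ring carbon.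

Two measured steps offer guidance. One is an at least 2.5-fold higher number from compound 1 to compound 2 (0.40 log units; beyond the scatter), and it can be tied to configuration alone because of the fact that compounds 1 and 2 differ only in the configuration as drawn. The other is an at least 2.5-fold higher number from compound 1 to compound 3 (0.40 log units; beyond the scatter), where acetyl replaces hydrogen on an oxygen on a saturated carbon. Both show that growth inhibition can be lost with a single change, but neither alters the chain that changes in compound 4. No clear shift is therefore expected in this assay, although some weakening remains possible. The expected change is a 1.1-fold higher number from compound 1 to compound 4 (0.05 log units; within the scatter), and it is not expected to lie beyond the scatter. For compound 4 the estimate is 22000 nM, with an expected range from 9000 nM to 50000 nM.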

Compound 4, concentration for 50% growth inhibition: 26200 nM
Compound 4: the middle estimate sits 1.2-fold (0.08 log units) below what was measured; low and high end bracket the measured number.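

In this assay, going by these compounds alone, the first change to the chain itself, ethyl to allyl, gives a result that stays within the scatter (a 1.3-fold higher number from compound 1 to compound 4 (0.12 log units; within the scatter)). The chain on the saturated ring carbon therefore accepts this added vinyl unit without a measurable change in growth inhibition. The two earlier single changes, one in configuration and one adding acetyl on the oxygen, had both shifted the result beyond the scatter, so this chain so far appears more forgiving than those two features, on the evidence of a single example.

As far as these compounds go, whether that holds for a clearly longer chain such as hexyl remains open. So does the effect of a chain ending in an amine or a carboxylic acid, which could show whether this position can give stronger inhibition of growth at all.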